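One added methyl on a methoxy group

The source may report more compounds than this note shows. Statements on the series, on what has been measured and on what is new or still open speak of the compounds shown alone.

In a functional assay on HeLa cells (Homo sapiens) for antiproliferative activity, read by MTT assay, with a stated time of 72 h (on this read-out lower numbers stand for stronger inhibition and higher numbers for weaker inhibition), compound 1 (`CCOc1ccc(-c2sc(NC)nc2-c2cc(OC)c(OC)c(OC)c2)cc1`) gives 13.2 nM and compound 2 (`COc1ccc(-c2sc(C)nc2-c2cc(OC)c(OC)c(OC)c2)cc1`) gives 500 nM as the higher of the two numbers, a gap beyond the scatter. Compound 3 (`CCOc1ccc(-c2sc(C)nc2-c2cc(OC)c(OC)c(OC)c2)cc1`) alters compound 2 in one place (methyl in place of hydrogen on a saturated chain carbon bound to an oxygen on an aromatic ring), turning methoxy to ethoxy. For the measured compounds named here, no measured pair shows this change alone. Compound 1 also carries the 4-ethoxyphenyl but differs elsewhere too, so its 13.2 nM is only a loose guide. A moderate drop in this assay is expected, an estimated 4.2-fold lower number from compound 2 to compound 3 (0.62 log units; beyond the scatter) toward stronger inhibition. For compound 3 the estimated value is 120 nM with a range from 25 nM to 600 nM expected.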

Compound 3, half-maximal inhibitory concentration: 1870 nM
For compound 3 the middle estimate is 16-fold (1.19 log units) below the measured one, outside the stated range (above it).
By their numbers in this assay, from the lowest: compound 1; then compound 2; then compound 3.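

In this assay, going from methoxy to ethoxy weakens inhibition, with a 3.7-fold higher number from compound 2 to compound 3 (0.57 log units; beyond the scatter), so the added methyl brings no gain at this position when methyl sits on the aromatic carbon that carries methylamino in compound 1. Putting methyl in place of methylamino costs far more, with a 140-fold higher number from compound 1 to compound 3 (2.15 log units; beyond the scatter), so the ethoxy group alone does not bring the low number of compound 1. No measurement shown here explains why either change acts this way.

From the compounds shown here alone, it remains open whether methoxy to ethoxy runs the same way when methylamino is present. Going by these compounds, how a longer chain such as propoxy, or an amine on that chain, would behave at this position also remains open.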